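The source may hold more compounds than are shown below. What is called first, only, known or untested is meant among the compounds shown, and "the series" means these compounds.

Compound 1 `CCCN(CCC)c1cc(C(F)(F)F)ccc1CNC(=O)C(C)c1ccc(NS(C)(=O)=O)c(F)c1`: 0.3 nM
Compound 2 `CCCCCCSc1cc(C(F)(F)F)ccc1CNC(=O)C(C)c1ccc(NS(C)(=O)=O)c(F)c1`: 1.8 nM

In an assay on CHO cells for antagonist activity at transient receptor potential cation channel subfamily V member 1 (Homo sapiens), read by FLIPR (on this read-out higher numbers stand for weaker inhibition and lower numbers for stronger inhibition), compound 1 gives 0.3 nM and compound 2 gives 1.8 nM. Among the compounds with values here, compound 2 thus stands at the higher of the two numbers, and the only measured step, a 6.0-fold higher number from compound 1 to compound 2 (0.78 log units; beyond the scatter), is the one that leads to it. Compound 3 `CCCCCc1cc(C(F)(F)F)ccc1CNC(=O)C(C)c1ccc(NS(C)(=O)=O)c(F)c1` differs from compound 2 in a single place: pentyl in place of hexylsulfanyl on an aromatic carbon. Within the data shown here, no measured step concerns this exchange, since the one step that exists swaps dipropylamino for hexylsulfanyl rather than hexylsulfanyl for pentyl. Among the measured compounds shown here, the two measured values show only that changing the group on this aromatic carbon can shift the number modestly. With nothing closer to rest on, a step of similar or smaller size is expected, a 1.7-fold higher number from compound 2 to compound 3 (0.22 log units; within the scatter), with no firm direction. Compound 3 is therefore estimated at 3 nM, within a range from 0.8 nM to 12 nM.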

Compound 3, inhibition constant: 0.4 nM
Estimate against measurement, compound 3: 7.5-fold (0.88 log units) above; the measured number lies below the stated range.
By their numbers in this assay, from the lowest: compounds 1 and 3 (each within the scatter of the next); then compound 2.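

In this assay the exchange of hexylsulfanyl for pentyl on this aromatic carbon gives a 4.5-fold lower number from compound 2 to compound 3 (0.65 log units; beyond the scatter) and so recovers most of what the first measured change gave up. The position therefore does not need a nitrogen at the point of attachment, since the all-carbon pentyl chain gives a 1.3-fold higher number from compound 1 to compound 3 (0.12 log units; within the scatter) and thus stands level with dipropylamino. Among these three compounds, compound 2 alone stands apart, with both of its steps beyond the scatter. Nothing measured here explains why the hexylsulfanyl compound differs from the other two.

The compounds shown do not separate the sulfur from the chain length, and a pentylsulfanyl or hexyl group would bear on that. They also leave open how short the chain can become, as with a propyl group, and whether an oxygen-linked chain such as hexyloxy behaves like pentyl or like hexylsulfanyl.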